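The source may report more compounds than this note shows. Statements on the series, on what has been measured and on what is new or still open speak of the compounds shown alone.

In an ADME assay on microsomes from liver (Mus musculus) for metabolic stability, with a stated time of 10 min (a lower number here means that less of the compound is left, a higher number that more of the compound is left), the measured compounds are:
compound 1 `Cc1cccc(C)c1COC(c1ccc([C@]2(S(=O)(=O)c3ccc(F)cc3)CCN(C(=O)[C@H]3CC[C@H](C(=O)O)CC3)C2)cc1)(C(F)(F)F)C(F)(F)F`: 77%
compound 2 `O=C(O)[C@H]1CC[C@H](C(=O)N2CC[C@](c3ccc(C(OCC4CC4)(C(F)(F)F)C(F)(F)F)cc3)(S(=O)(=O)c3ccc(F)cc3)C2)CC1`: 44%

Compound 2 holds the lower of these two numbers. Compound 3 `O=C(O)[C@H]1CC[C@H](C(=O)N2CC[C@](c3ccc(C(OCC4CCC4)(C(F)(F)F)C(F)(F)F)cc3)(S(=O)(=O)c3ccc(F)cc3)C2)CC1` differs from it by a single change, (cyclobutyl in place of cyclopropyl on a saturated chain carbon bound to an oxygen on a saturated carbon), which puts cyclobutyl in place of cyclopropyl. Among the compounds with values here, the only measured step at this place is a number 33 percentage points lower from compound 1 to compound 2 (beyond the scatter), a large one, with cyclopropyl in place of 2,6-dimethylphenyl. It shows that this place can matter, but it gives no direction for exchanging one non-aromatic carbon ring for another. Only a modest change is therefore expected, and the estimated step, a number 1 percentage points higher from compound 2 to compound 3 (within the scatter), stays within the scatter. The estimate for compound 3 is 45%, with an expected range of 30% to 60%.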

Compound 3, percent of the compound remaining: 39%
For compound 3 the middle estimate is 6 percentage points above the measured one; measured number inside the range.
By their numbers in this assay, from the lowest: compounds 3 and 2 (each within the scatter of the next); then compound 1.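

In this assay, cyclobutyl in place of cyclopropyl gives a number 5 percentage points lower from compound 2 to compound 3 (within the scatter), so at this place these two non-aromatic carbon rings cannot be told apart. Cyclobutyl in place of 2,6-dimethylphenyl gives a number 38 percentage points lower from compound 1 to compound 3 (beyond the scatter), so the large step seen with cyclopropyl appears with a second non-aromatic ring as well. Nothing on hand explains these numbers.

The compounds shown leave open how an open chain such as isobutyl, or a ring holding an amine, would compare at this place. They also leave open whether plain phenyl would stand with compound 1 or with compound 2 and compound 3.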